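The source may hold more compounds than are shown below. What is called first, only, known or untested is meant among the compounds shown, and "the series" means these compounds.

- compound 1 `COc1cc(OC)c(C(=O)/C=C/c2ccccc2OC)c(OC)c1`: 8700 nM
- compound 2 `COc1cc(OC)c(C(=O)/C=C/c2ccccc2)c(OC)c1`: 7200 nM

Both numbers come from a functional assay on HaCaT cells (Homo sapiens) for cytotoxicity, with a stated time of 48 h; a higher number here means a weaker inhibitor, a lower number a stronger inhibitor. For the measured compounds named here, with only two compounds measured, there is little to compare: compound 2, at 7200 nM, cannot be told apart from compound 1, since the gap between them lies within the scatter.

The next compound to be measured is compound 3 `COc1cc(OC)c(C(=O)/C=C/c2ccc(Cl)cc2)c(OC)c1`. It differs from compound 2 in one place, with chloro in place of hydrogen on an aromatic carbon, para to a large group (chloro in place of hydrogen on an aromatic carbon). The same difference can be read as phenyl to 4-chlorophenyl.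

Going by the values given here, only one measured step offers any guidance: a 1.2-fold lower number from compound 1 to compound 2 (0.08 log units; within the scatter). That step swapped hydrogen for methoxy rather than introducing chloro, so it bears on the new change only loosely. Among the compounds with values here, no measured compound carries chloro, so the data give no direct sign of what this group does here. The expectation is therefore a small step, with no firm direction. The expected step is a 1.3-fold lower number from compound 2 to compound 3 (0.12 log units; within the scatter). For compound 3, the estimate in this assay is 5500 nM, with an expected range of 2000 nM to 15000 nM.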

Compound 3, half-maximal inhibitory concentration: 7600 nM
Compound 3: the middle estimate sits 1.4-fold (0.14 log units) below what was measured; low and high end bracket the measured number.
By their numbers in this assay, from the lowest: compounds 2, 3 and 1 (each within the scatter of the next).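

In this assay, chloro in place of hydrogen on an aromatic carbon, para to a large group, gives a 1.1-fold higher number from compound 2 to compound 3 (0.02 log units; within the scatter) and so leaves compound 2 and compound 3 indistinguishable. For the compounds shown here, this is the first sign that a substituent at this place on the ring need not produce a measurable shift in this cytotoxicity read-out, though it rests on a single group. The wider swap of 2-methoxyphenyl for 4-chlorophenyl gives a 1.1-fold lower number from compound 1 to compound 3 (0.06 log units; within the scatter) as well, so the three compounds, carrying 2-methoxyphenyl, phenyl and 4-chlorophenyl on the shared core, cannot be ranked, and no measured evidence is at hand to explain this flat result.

Still open, as far as these compounds go, is whether a different kind of group at this same place, such as an amine or a carboxylic acid, would move the number beyond the scatter. Also open, from the compounds shown here alone, is whether chloro at another place on this ring, or a longer chain in place of chloro, would give a clearer difference between compounds.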